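This account rests on a few compounds, and the source may have more. Where it says the series, first, only, none or still open, it means among the compounds named here.

Measured compounds in a functional assay on MIA PaCa-2 cells (Homo sapiens) for inhibition, read by MTT assay, with a stated time of 3 days; a higher number here means a weaker inhibitor, a lower number a stronger inhibitor:
compound 1 `CCOC(=O)[C@@H]1CCCN(S(=N)(=O)c2ccc(S(=O)(=O)N(CC)CC)cc2)C1` gives > 10000 nM, a limit of the assay rather than a number.
compound 2 `CCN(CC)S(=O)(=O)c1ccc(S(=O)(=O)N2CCC[C@@H](C(=O)N(C)C(C)C)C2)cc1` gives > 10000 nM, likewise a limit of the assay.
compound 3 `CCOC(=O)[C@@H]1C[C@H](O)CN(S(=O)(=O)c2ccc(S(=O)(=O)N(CC)CC)cc2)C1` gives > 10000 nM, again a limit of the assay.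

Compound 2 therefore stands where the whole series stands so far: the limit of > 10000 nM in this assay, at which 3 of the 3 values shown sit. Going by the values given here, no step between two measured compounds is available, so the data give no measure of how a change on the carbonyl carbon moves the read-out. Compound 4 `CCN(CC)S(=O)(=O)c1ccc(S(=O)(=O)N2CCC[C@@H](C(=O)N3CCN(c4nc(C)no4)CC3)C2)cc1` differs from compound 2 in one place: 4-(3-methyl-1,2,4-oxadiazol-5-yl)piperazin-1-yl in place of isopropyl(methyl)amino on a carbonyl carbon. The expected step in this assay is a step that the limit leaves unreadable from compound 2 to compound 4, that is, none beyond the scatter, with the value most likely remaining a limit. Compound 4 is estimated at 15000 nM, within 3000 nM to 60000 nM.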

Compound 4, half-maximal inhibitory concentration: > 10000 nM
Compound 4 gave a limit, no number; the forecaster's own chance of this, stated with the estimate: 75%; the middle value lies beyond the limit too.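

No step can be read from compound 2 to compound 4, since each gives only a limit: the limit of > 10000 nM in this assay, at which 4 of the 4 values shown sit. In this assay the compounds shown leave open whether any change on the carbonyl carbon gives a readable value.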